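This account rests on a few compounds, and the source may have more. Where it says the series, first, only, none or still open, it means among the compounds named here.

Of the compounds shown here, three built on one shared core have been tested in a functional assay on MCF7 cells (Homo sapiens) for cytotoxicity, read by MTT assay, with a stated time of 72 h; a higher number here means a weaker inhibitor, a lower number a stronger inhibitor. Compound 1 `COc1ccc(/C=C/C(=O)Nc2cc3c(Nc4ccc(F)c(Cl)c4)ncnc3cc2OC)c(OC)c1` gives 36600 nM. Compound 2 `O=C(/C=C/c1cccc(Cl)c1Cl)Nc1cc2c(Nc3ccc(F)c(Cl)c3)ncnc2cc1O[C@H]1CCOC1` gives 30100 nM, and compound 3 `COc1cc(/C=C/C(=O)Nc2cc3c(Nc4ccc(F)c(Cl)c4)ncnc3cc2O[C@H]2CCOC2)cc(OC)c1` gives 30300 nM. The three numbers sit within the usual scatter of one another, so compound 1 stands level with the other two rather than apart from them. Compound 4 `COc1cc2ncnc(Nc3ccc(F)c(Cl)c3)c2cc1NC(=O)/C=C/c1ccc(C#N)cc1` differs from compound 1 in the group hung on the chain: 4-cyanophenyl in place of 2,4-dimethoxyphenyl on a double-bonded chain carbon bound to a double-bonded chain carbon. One earlier step changes the group at the same place, the swap of 2,3-dichlorophenyl for 3,5-dimethoxyphenyl, and it moved the number by a 1.0-fold higher number from compound 2 to compound 3 (0.00 log units; within the scatter). Among the compounds with values here, with only that single comparison to lean on, and it lying within the scatter, the expectation for the present swap is a step of no more than the scatter in either direction. Compound 4 is therefore expected to give about 34000 nM, within a range from 12000 nM to 95000 nM, which is an expected step of a 1.1-fold lower number from compound 1 to compound 4 (0.03 log units; within the scatter).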

Compound 4, half-maximal inhibitory concentration: "not active" (no number reported)
Nothing numeric was reported for compound 4; the estimate stays without a comparison.
By their numbers in this assay, from the lowest: compounds 2, 3 and 1 (each within the scatter of the next).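

In this assay, within the data shown here, compound 4 is reported only as "not active", without a number, so no step from compound 1 to compound 4 can be read. From the compounds shown here alone, how the 4-cyanophenyl group compares with 2,4-dimethoxyphenyl in size of effect stays open. Nothing available here bears on this result.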